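Methylsulfonyl in Place of Methyl: An Expected Step

The compounds below may be only part of what the source reports. "The series", "measured", "known", "first", "only" and "open" are said of these compounds alone.

Measured compounds, with their numbers in a functional assay for antagonist activity at P2X purinoceptor 7 (Rattus norvegicus), read by FLIPR and calcium flux; on this read-out lower numbers stand for stronger inhibition and higher numbers for weaker inhibition:
- compound 1 `Cc1ccccc1Nc1ncnn1-c1cccc(Cl)c1Cl`: 240 nM
- compound 2 `COc1ccccc1Nc1ncnn1-c1cccc(Cl)c1Cl`: 2040 nM
- compound 3 `Cc1ccccc1CNc1ncnn1-c1cccc(Cl)c1Cl`: 200 nM

Compound 3 carries the lowest number of the three in this assay, but its gap to compound 1 is within the scatter, so no order between those two can be claimed; compound 2 stands clearly higher. Compound 4 `CS(=O)(=O)c1ccccc1CNc1ncnn1-c1cccc(Cl)c1Cl` is not yet measured. It differs from compound 3 by methylsulfonyl in place of methyl on an aromatic carbon. Within the data shown here, the only measured step that bears on it is an 8.5-fold higher number from compound 1 to compound 2 (0.93 log units; beyond the scatter), where a polar group took the place of the methyl on the same ring. By analogy compound 4 is expected to show a higher number, a step of a 7.5-fold higher number from compound 3 to compound 4 (0.88 log units; beyond the scatter), with an estimate of 1500 nM, between 400 nM and 6000 nM.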

Compound 4, half-maximal inhibitory concentration: 39.8 nM
Estimate against measurement, compound 4: 38-fold (1.58 log units) above; the measured number lies below the stated range.
By their numbers in this assay, from the lowest: compound 4; then compounds 3 and 1 (each within the scatter of the next); then compound 2.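

In this assay, the place ortho to a large group on the ring of compound 3 takes methylsulfonyl with a lower number (a 5.0-fold lower number from compound 3 to compound 4 (0.70 log units; beyond the scatter)). The earlier change from methyl to methoxy went the other way (an 8.5-fold higher number from compound 1 to compound 2 (0.93 log units; beyond the scatter)), so replacing this methyl does not always raise the number, although those two steps differ in the entering group and in the rest of the compound. Nothing shown here explains the direction of the new step. From the compounds shown here alone, whether an amine or a carboxylic acid at this place would also lower the number remains open. So does whether methylsulfonyl would do the same on the core of compound 1.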